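Swapping a methyl for a bromo on the ring that hangs off the core

A few compounds are considered here, and "the series" means these few. Any claim that something is new, unique, unknown or untested is made for them only; others in the source may bear on it.

The measured compounds and their numbers:
compound 1 `CC(C)(C)c1cc(NC(=O)Nc2ccc(F)c(F)c2)n(-c2ccccc2)n1` gives 3.4 degrees C
compound 2 `CC(C)(C)c1cc(NC(=O)Nc2ccccc2)n(-c2ccccc2)n1` gives 7.2 degrees C
compound 3 `Cc1ccc(-n2nc(C(C)(C)C)cc2NC(=O)Nc2cc(C(F)(F)F)cc(C(F)(F)F)c2)cc1` gives -0.5 degrees C

These numbers come from an assay on isolated protein for inhibition of serine/threonine-protein kinase 10 (Homo sapiens), read by thermal shift assay, tested at 10 uM; a lower number here means that the compound stabilises the target less, a higher number that the compound stabilises the target more against heat. Compound 3 stands lowest of the three; compound 1 lies nearest, and compound 2 lies furthest from it. Within the data shown here, the one measured step, a number 3.8 degrees C higher from compound 1 to compound 2 (beyond the scatter), concerns the ring on the amide-type nitrogen and shows that changes there can move the number by a modest amount.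

Compound 4 `CC(C)(C)c1cc(NC(=O)Nc2cc(C(F)(F)F)cc(C(F)(F)F)c2)n(-c2ccc(Br)cc2)n1` has not yet been measured. It differs from compound 3 by bromo in place of methyl on an aromatic carbon. Among the measured compounds shown here, this change sits on the other ring, the one attached to the core itself, and no measured pair speaks to that ring. With nothing comparable to draw on, the expectation is a step of no clear size beyond the scatter, so the estimate for compound 4 is 0 degrees C, within -2 degrees C to 2.5 degrees C, which as an expected step is a number 0.50 degrees C higher from compound 3 to compound 4 (within the scatter).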

Compound 4, shift of the target's melting temperature: -0.3 degrees C
For compound 4 the middle estimate is 0.30 degrees C above the measured one; low and high end bracket the measured number.
By their numbers in this assay, from the lowest: compounds 3 and 4 (each within the scatter of the next); then compound 1; then compound 2.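

In this assay, among these compounds, the pair of compound 3 and compound 4 is the first to speak to the ring attached to the core, and bromo in place of methyl on that ring gives a number 0.20 degrees C higher from compound 3 to compound 4 (within the scatter). With the rest of the molecule the same, 4-methylphenyl and 4-bromophenyl cannot be told apart by this read-out, and both numbers lie close to zero. No evidence is at hand that would explain this result.

As far as these compounds go, whether the same swap would matter on a compound with a higher number remains open, as compound 1 and compound 2 carry a plain phenyl on that ring and have no bromo or methyl partner here. From the compounds shown here alone, how an amine or a carboxylic acid in the same place would read is also open.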